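A few compounds are considered here, and "the series" means these few. Any claim that something is new, unique, unknown or untested is made for them only; others in the source may bear on it.

Measured so far:
Compound 1 `O=C(O)CCc1ccc(OCC2COc3cc(Br)ccc3O2)cc1F` gives 980 nM in a functional assay on HEK293 cells for agonist activity at Free fatty acid receptor 1 (Homo sapiens), read by fluorescence and calcium flux, with a stated time of 10 min; on this read-out higher numbers stand for an effect only at larger amounts of compound and lower numbers for an effect already at smaller amounts.
Compound 2 `CC#CC(CC(=O)O)c1ccc(OCC2COc3ccc(Cl)cc3O2)cc1` gives 100 nM in this assay.

Compound 2 holds the lower of these two numbers, and its gap to compound 1 lies beyond the usual scatter. Compound 3 `Cn1ccnc1C(CC(=O)O)c1ccc(OCC2COc3ccc(Cl)cc3O2)cc1` is not yet measured; it keeps the core of compound 2 and carries 1-methyl-1H-imidazol-2-yl in place of prop-1-yn-1-yl on a saturated chain carbon bound to an aromatic carbon and a saturated chain carbon. Among the compounds with values here, no measured pair shows this change directly, so its effect is uncertain. A modest step toward a higher number in this assay is expected, a 2.5-fold higher number from compound 2 to compound 3 (0.40 log units; beyond the scatter), with the outcome for compound 3 estimated at 250 nM, somewhere between 60 nM and 1000 nM.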

Compound 3, half-maximal effective concentration: 5880 nM
Estimate against measurement, compound 3: 24-fold (1.37 log units) below; the whole stated range lies below it.
By their numbers in this assay, from the lowest: compound 2; then compound 1; then compound 3.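

In this assay, within the data shown here, this position, on a saturated chain carbon bound to an aromatic carbon and a saturated chain carbon, proves highly sensitive: 1-methyl-1H-imidazol-2-yl in place of prop-1-yn-1-yl brings a 59-fold higher number from compound 2 to compound 3 (1.77 log units; beyond the scatter) and so a large loss, which no earlier pair could reveal. Much more of an effect is then needed once this aromatic ring replaces the triple-bonded chain. Nothing measured here accounts for the size of this step.

From the compounds shown here alone, whether a phenyl ring, a plain methyl group or an amine at this carbon would behave more like compound 2 or compound 3 stays open.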